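The compounds below may be only part of what the source reports. "The series", "measured", "known", "first", "only" and "open" are said of these compounds alone.

Within the data shown here, in an ADME assay on MT4 cells (Homo sapiens) for cytotoxicity (on this read-out higher numbers stand for lower toxicity in this test and lower numbers for higher toxicity in this test), compound 1 (`CCCCCCCCCCCCCCCCC(OP(=O)(O)OC[C@@H]1C=C[C@H](n2cc(C)c(=O)[nH]c2=O)O1)C(=O)O`) gives 64700 nM, the only actual number so far. Compound 2 (`CCCCCCCCCCCCCCCC(CC(=O)O)OP(=O)(O)OC[C@@H]1C=C[C@H](n2cc(C)c(=O)[nH]c2=O)O1`) reads > 198000 nM, which is a limit of the assay and not a number. Compound 3 (`CCCCCCCCCCCCCCCCC(OP(=O)(O)OC[C@@H]1C=C[C@H](n2cnc3c(N)ncnc32)O1)C(=O)O`) differs from compound 1 at one place, on a saturated ring carbon next to the ring oxygen: a group of 10 heavy atoms (5 carbon, 5 nitrogen; one five-membered aromatic ring with 2 hetero atoms, one six-membered aromatic ring with 2 hetero atoms) in place of a group of 9 heavy atoms (5 carbon, 2 nitrogen, 2 oxygen; one six-membered aromatic ring with 2 hetero atoms), on a saturated ring carbon. Among the measured compounds shown here, no measured step covers this exchange, so no shift beyond the scatter is expected in this assay. The expected change is a 1.1-fold lower number from compound 1 to compound 3 (0.03 log units; within the scatter). For compound 3 the estimate is 60000 nM, with an expected range of 20000 nM to 180000 nM.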

Compound 3, half-maximal cytotoxic concentration: 97800 nM
Compound 3: the middle estimate sits 1.6-fold (0.21 log units) below what was measured; low and high end bracket the measured number.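

In this assay, among these compounds, the exchange on the saturated ring carbon next to the ring oxygen gives the first readable step: a 1.5-fold higher number from compound 1 to compound 3 (0.18 log units; within the scatter). At this position, the group of 10 heavy atoms with its two aromatic rings therefore causes no shift beyond the scatter relative to the group of 9 heavy atoms. Compound 2 carries a limit and not a number, so it gives no step: the limit of > 198000 nM in this assay, at which 1 of the 3 values shown sits.

On these data alone, whether a shorter chain would shift the read-out remains open. So does the effect of an amide in place of the carboxylic acid.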